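The source may hold more compounds than are shown below. What is called first, only, known or untested is meant among the compounds shown, and "the series" means these compounds.

Measured so far in a functional assay on A-375 cells (Homo sapiens) for antiproliferative activity, read by CCK-8 assay, with a stated time of 72 h, tested at 2 uM; a higher number here means a stronger effect of the compound at the concentration tested, a lower number a weaker effect:
compound 1 `Nc1ccccc1NC(=O)c1ccc(CSC(=S)N2CCc3cc([N+](=O)[O-])ccc32)cc1` gives 16.9%
compound 2 `CC1CCCCN1C(=S)SCc1ccc(C(=O)Nc2ccccc2N)cc1` gives 42.5%
compound 3 `Nc1ccccc1NC(=O)c1ccc(CSC(=S)N2CCc3ccc([N+](=O)[O-])cc32)cc1` gives 22.1%

Compound 2 holds the highest of the three numbers in this assay. The nearest to it is compound 3, whose number lies lower by a margin beyond the scatter; compound 1 lies furthest, its number lower by a margin also beyond the scatter. Among the measured compounds shown here, compounds 1 and 3 differ from compound 2 at more than one place, so no single step between any pair of the measured compounds can be read off, and nothing about the effect of one isolated change is known from them.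

Compound 4 `CC1CCN(C(=S)SCc2ccc(C(=O)Nc3ccccc3N)cc2)CC1` is not yet measured. The change from compound 2 is 4-methylpiperidin-1-yl in place of 2-methylpiperidin-1-yl on a thiocarbonyl carbon. The two are built from the same atoms and differ only in where the methyl sits on the ring; the thiocarbonyl carbon and everything beyond it are unchanged. For the measured compounds named here, no measured pair shows a change of this kind, so the size of the step has no precedent here. The expectation is a step within the scatter, with at most a small move downward.

For compound 4 the estimate in this assay is 38%, with a range from 20% to 56%. This estimate means an expected step of a number 4.5 percentage points lower from compound 2 to compound 4 (within the scatter).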

Compound 4, a percentage reported as inhibition, at one concentration (the size of the read-out at that concentration, not a potency): 32.7%
The estimate for compound 4 lay 5.3 percentage points above the measured number; the range from low to high includes it.
By their numbers in this assay, from the lowest: compounds 1 and 3 (each within the scatter of the next); then compounds 4 and 2 (each within the scatter of the next).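

In this assay, among the compounds shown here, 4-methylpiperidin-1-yl in place of 2-methylpiperidin-1-yl on a thiocarbonyl carbon gives a number 9.8 percentage points lower from compound 2 to compound 4 (within the scatter), the first step that can be read for one isolated change; steps involving compounds 1 and 3 still cannot be read. The two groups have the same atoms and differ only in where the methyl sits on the ring, so at this single test concentration the read-out does not separate these two methyl placements, and neither compound 2 nor compound 4 can be ranked over the other. No measured evidence on the compounds bears on this result, so the data give no explanation for it.

Open, from the compounds shown here alone, is how this thiocarbonyl carbon would read with piperidin-1-yl carrying no methyl, with 3-methylpiperidin-1-yl, with a longer chain such as 4-ethylpiperidin-1-yl, or with a ring holding a second hetero atom such as morpholin-4-yl. Also open, going by these compounds, is whether compound 2 and compound 4 would stay within the scatter of each other at other concentrations, as one percentage at one concentration is not a potency.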